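The source may hold more compounds than are shown below. What is called first, only, known or untested is meant among the compounds shown, and "the series" means these compounds.

Measured compounds:
compound 1, `O=C(CO[N+](=O)[O-])NNC(=O)c1ccc(-n2[nH]c(=O)cc2-c2ccc([N+](=O)[O-])cc2)cc1`, gives 24% in a functional assay on the whole organism (strain Wistar) for inhibition, with Rattus norvegicus as the target, read by paw edema, with stated times of 3 h and 1 h, at a dose of 6 mg/kg by the oral route; on this read-out lower numbers stand for less inhibition and higher numbers for more inhibition at the one dose given (going by the name of the read-out).
compound 2, `COc1ccccc1-c1cc(=O)[nH]n1-c1ccc(C(=O)NNC(=O)CO[N+](=O)[O-])cc1`, gives 57.9% in this assay.
compound 3, `O=C(CO[N+](=O)[O-])NNC(=O)c1ccc(-n2[nH]c(=O)cc2-c2ccc(Cl)cc2)cc1`, gives 5.84% in this assay.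

Compound 3 stands lowest of the three, with a number 18.2 percentage points lower from compound 1 to compound 3 (beyond the scatter) and a number 52.1 percentage points lower from compound 2 to compound 3 (beyond the scatter) both beyond the scatter. The step from compound 3 to compound 4, `O=C(CO[N+](=O)[O-])NNC(=O)c1ccc(-n2[nH]c(=O)cc2-c2ccccc2)cc1`, is hydrogen in place of chloro on an aromatic carbon. Within the data shown here, only one measured step touches the same place: from compound 1 to compound 3 the nitro became chloro and the read-out fell, a number 18.2 percentage points lower from compound 1 to compound 3 (beyond the scatter), a modest drop. Nothing measured shows what a plain hydrogen does at that position; the large swing a number 33.9 percentage points higher from compound 1 to compound 2 (beyond the scatter) concerns a different aromatic ring and does not bear on this step. With the chloro gone, a move back up toward the level of compound 1 seems the most likely outcome, yet it rests on a single step, so the expectation stays loose. The step of a number 14.2 percentage points higher from compound 3 to compound 4 (beyond the scatter) is therefore expected to be a modest rise, and compound 4 is estimated at 20%, within the range 5% to 45%.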

Compound 4, a percentage reported as inhibition, in the whole organism at one dose (the size of the read-out at that dose, not a potency): 20.5%
Compound 4: middle estimate off by 0.5 percentage points, on the low side, and the stated range covers the measured number.
By their numbers in this assay, from the lowest: compound 3; then compounds 4 and 1 (each within the scatter of the next); then compound 2.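

Among the groups tested at this place on the aromatic ring, chloro is the one that stands apart in this assay: removing it gives a number 14.7 percentage points higher from compound 3 to compound 4 (beyond the scatter), whereas the comparison with nitro gives a number 3.5 percentage points lower from compound 1 to compound 4 (within the scatter), so the plain phenyl and 4-nitrophenyl compounds cannot be told apart on this read-out. Hydrogen also provides a baseline for the 2-methoxyphenyl compound, with a number 37.4 percentage points lower from compound 2 to compound 4 (beyond the scatter), so that group stands clearly apart from an unsubstituted phenyl ring. Nothing available explains why chloro differs from hydrogen or nitro here.

From the compounds shown here alone, whether fluoro or bromo at this place would track chloro or hydrogen remains open. So does the outcome for an amine, a carboxylic acid or a methoxy group at the same place.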